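This account rests on a few compounds, and the source may have more. Where it says the series, first, only, none or still open, it means among the compounds named here.

Measured compounds:
compound 1, `CC(=O)Nc1ccc2nc(SCC(=O)NCc3ccc(Cl)cc3)sc2c1`, 6700 nM
compound 2, `CNC(=O)CSc1nc2ccc(NC(=O)c3ccc([N+](=O)[O-])cc3)cc2s1`, > 100000 nM
compound 3, `O=C(CSc1nc2ccc(NC(=O)c3ccc([N+](=O)[O-])cc3)cc2s1)NCc1ccc(Cl)cc1`, > 100000 nM

In a functional assay on HepG2 cells (Homo sapiens) for cytotoxicity, read by MTT assay, with a stated time of 48 h (a lower number here means a stronger inhibitor, a higher number a weaker inhibitor), compound 1 gives 6700 nM. For compound 2 the result is only a limit of the assay, > 100000 nM. For compound 3 the result is likewise only a limit, > 100000 nM.

Compound 1 and compound 3 share a core and differ in one place: methyl in place of 4-nitrophenyl on a carbonyl carbon. That change gave an at least 14-fold lower number from compound 3 to compound 1 (1.17 log units; beyond the scatter). Compound 2 and compound 3 differ in another place: hydrogen in place of 4-chlorophenyl on a saturated chain carbon bound to an amide-type nitrogen. The step between them, a step that the two limits leave unreadable from compound 2 to compound 3, cannot be read, since both values are limits; the limit of > 100000 nM in this assay, at which 2 of the 3 values shown sit, is where two of the three measured values sit.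

Compound 4, `CNC(=O)CSc1nc2ccc(NC(C)=O)cc2s1`, has not yet been measured in this assay. It differs from compound 2 by methyl in place of 4-nitrophenyl on a carbonyl carbon, the same change, at the same place, that turns compound 3 into compound 1. As compound 2 sits at the limit (the limit of > 100000 nM in this assay, at which 2 of the 3 values shown sit), the step from compound 2 to compound 4 is expected to lead to a numerical value, and is estimated as an at least 5.0-fold lower number from compound 2 to compound 4 (0.69 log units; beyond the scatter), resting on the step of an at least 14-fold lower number from compound 3 to compound 1 (1.17 log units; beyond the scatter) seen for the same change. Compound 4 is therefore expected to give about 20000 nM in this assay, with a range from 5000 nM to 100000 nM.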

Compound 4, half-maximal inhibitory concentration: > 100000 nM
Compound 4: a limit, no number; the forecaster's own chance of this, stated with the estimate: 35%; middle value at least 5.0-fold (0.69 log units) away from the limit.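

In this assay compound 4 gives > 100000 nM, which is a limit of the assay and not a number. Methyl in place of 4-nitrophenyl on a carbonyl carbon gave a readable number only in compound 1, which carries the 4-chlorophenyl group, so among these compounds the change did not carry over to the core without that group as a readable gain, and the loss of 4-chlorophenyl with methyl in place is large and beyond the scatter, with an at least 14-fold higher number from compound 1 to compound 4 (1.17 log units; beyond the scatter). This does not show that the change does nothing on the core of compound 2, since steps that join two limits cannot be read, and most of the series sits at that limit: the limit of > 100000 nM in this assay, at which 3 of the 4 values shown sit.

Going by these compounds alone, with compound 1 as the only compound that carries a number, the size of the change on either core remains unknown, and no trend can be drawn from a single value. Also open, on these data alone, is whether a longer chain or an amine in place of methyl on the carbonyl carbon would keep a number, and whether a carboxylic acid in place of 4-chlorophenyl on the saturated chain carbon would do the same.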